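A few compounds are considered here, and "the series" means these few. Any claim that something is new, unique, unknown or untested is made for them only; others in the source may bear on it.

Working notes on the sulfonamide series.

Three members of the series have been run in a functional assay on ASPC1 cells (Homo sapiens) for inhibition, read by MTT assay, with a stated time of 72 h; on this read-out higher numbers stand for weaker inhibition of growth and lower numbers for stronger inhibition of growth. Compound 1 `CC(C)(C)c1ccc(CNCCCNS(=O)(=O)c2cc(C(F)(F)F)cc(C(F)(F)F)c2)cc1` gives 2700 nM in this assay. Compound 2 `O=S(=O)(NCCCNCC1COc2ccccc2O1)c1cc(C(F)(F)F)cc(C(F)(F)F)c1` gives 2900 nM. Compound 3 `COc1ccc(CNCCCNS(=O)(=O)c2cc(C(F)(F)F)cc(C(F)(F)F)c2)cc1` gives 2800 nM, which places it second highest of the three numbers, with compound 2 nearest and compound 1 furthest, both separations within the scatter.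

The measured steps all concern the group on the saturated chain carbon bound to the amine nitrogen and its substituent. From compound 1 to compound 2 the step was a 1.1-fold higher number from compound 1 to compound 2 (0.03 log units; within the scatter). From compound 1 to compound 3 it was a 1.0-fold higher number from compound 1 to compound 3 (0.02 log units; within the scatter). From compound 2 to compound 3 it was a 1.0-fold lower number from compound 2 to compound 3 (0.02 log units; within the scatter).

Compound 4 `O=S(=O)(NCCCNCc1ccc(Cl)cc1)c1cc(C(F)(F)F)cc(C(F)(F)F)c1` is not yet measured. It differs from compound 3 by chloro in place of methoxy on an aromatic carbon. The step from compound 1 to compound 3 is the one that bears most directly on it, as it also alters the substituent on that aromatic carbon, and it stayed within the scatter, as did the two steps exchanging the whole benzyl-type group. No movement beyond the scatter is therefore expected in this assay; the expected step is no change at the digits printed from compound 3 to compound 4 (within the scatter). For compound 4 the estimate in this assay is 2800 nM, with a range from 1300 nM to 6000 nM.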

Compound 4, concentration for 50% growth inhibition: 3000 nM
Estimate against measurement, compound 4: 1.1-fold (0.03 log units) below; low and high end bracket the measured number.
By their numbers in this assay, from the lowest: compounds 1, 3, 2 and 4 (each within the scatter of the next).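

In this assay, chloro in place of methoxy on an aromatic carbon, para to a large group, gives a 1.1-fold higher number from compound 3 to compound 4 (0.03 log units; within the scatter) and so takes out the oxygen of the methoxy group and its one hydrogen-bond acceptor with no step beyond the scatter. Chloro in place of tert-butyl at the same carbon gives a 1.1-fold higher number from compound 1 to compound 4 (0.05 log units; within the scatter) and 4-chlorophenyl in place of 2,3-dihydro-1,4-benzodioxin-2-yl gives a 1.0-fold higher number from compound 2 to compound 4 (0.01 log units; within the scatter) so a halogen now joins the alkyl and alkoxy groups at this position, and all four compounds lie within the scatter of one another. Nothing measured alongside these numbers accounts for this flat picture.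

The compounds shown leave open whether a carboxylic acid or a dimethylamino group on that aromatic carbon would also stay within the scatter, as every group seen there so far carries no net charge. Also open, from the compounds shown here alone, is how the series responds to change elsewhere in the shared core, such as a longer chain linking the sulfonamide and the amine, or a nitrile in place of trifluoromethyl.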